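Shortening the acyl chain in a glutamate receptor modulator series

The source may report more compounds than this note shows. Statements on the series, on what has been measured and on what is new or still open speak of the compounds shown alone.

Measured compounds:
compound 1, `Cc1c(OCCCCOc2ccc(C(=O)C(C)C)c(O)c2C)cccc1C(=O)O`, 149 nM;
compound 2, `CCC(=O)c1ccc(OCCCCOc2cccc(C(=O)O)c2C)c(C)c1O`, 62 nM;
compound 3, `CCC(=O)c1ccc(OCCCCOc2ccc(C(=O)O)cc2C)c(C)c1O`, 82 nM.

All three were tested in an assay on HEK293 cells for positive allosteric modulation of metabotropic glutamate receptor 2 (Rattus norvegicus), read by thallium flux, with a stated time of 2.5 min; on this read-out higher numbers stand for an effect only at larger amounts of compound and lower numbers for an effect already at smaller amounts. The change hydrogen in place of methyl on a saturated chain carbon bound to a carbonyl carbon and a saturated chain carbon gave a 2.4-fold lower number from compound 1 to compound 2 (0.38 log units; beyond the scatter). Compound 3 and compound 2 lie within the scatter of each other; the difference between the two cores is not broken down here. Compound 4, `CC(=O)c1ccc(OCCCCOc2ccc(C(=O)O)cc2C)c(C)c1O`, is not yet measured and carries the change (hydrogen in place of methyl on a saturated chain carbon bound to a carbonyl carbon). This is the same kind of change as the earlier one, but the place differs: there the carbon was also bound to a saturated chain carbon, here only to the carbonyl carbon. A somewhat smaller step, a 1.4-fold lower number from compound 3 to compound 4 (0.14 log units; within the scatter), is expected, resting on the step from compound 1 to compound 2 and on the unmatched place. Compound 4 is estimated at 60 nM, between 25 nM and 150 nM.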

Compound 4, half-maximal effective concentration: 50 nM
For compound 4 the middle estimate is 1.2-fold (0.08 log units) above the measured one; low and high end bracket the measured number.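

On the core of compound 3, propanoyl to acetyl gives a 1.6-fold lower number from compound 3 to compound 4 (0.21 log units; within the scatter) in this assay, so this step on its own cannot be told apart from repeat measurement. Set beside the earlier step on the other core, it does not differ from it: the same change on two cores in this assay, a 2.4-fold lower number (0.38 log units; beyond the scatter) from compound 1 to compound 2 and a 1.6-fold lower number (0.21 log units; within the scatter) from compound 3 to compound 4, 1.5-fold (0.17 log units) apart, within the scatter of two such steps. Within the data shown here, this shows that the two cores are compatible with one shared effect of the change, but it does not establish that the effect carries over, as there is only one pair per core and the carbon that changes is bound differently in each pair.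

The compounds shown leave open how the acetyl change would read on the core of compound 2. They also leave open what an amide or a tetrazole in place of the carboxylic acid would give.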